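Piperidine attachment point and rat microsomal stability

The source may report more compounds than this note shows. Statements on the series, on what has been measured and on what is new or still open speak of the compounds shown alone.

Compound 1 `c1ccc2c(c1)CN[C@@H](CN(CC[C@H]1CCCNC1)[C@H]1CCCc3cccnc31)C2` is the least stable of the three measured compounds in an ADME assay on microsomes from liver (Rattus norvegicus) for metabolic stability, read by LC-MS, with a stated time of 10 min, tested at 0.5 uM (on this read-out higher numbers stand for a more stable compound and lower numbers for a less stable compound), where compound 1 gives 55%. For the measured compounds named here, compound 2 `c1ccc2c(c1)CN[C@H](CN(CCCN1CCNCC1)[C@H]1CCCc3cccnc31)C2` gives 88% in this assay and compound 3 `c1cnc2c(c1)CN[C@H](CN(CCCN1CCNCC1)[C@H]1CCCc3cccnc31)C2` gives 87%; the only single-point step among the measured compounds, a number 1 percentage points lower from compound 2 to compound 3 (within the scatter), concerns the aromatic ring of the core and not the chain. Compound 4 `c1ccc2c(c1)CN[C@@H](CN(CCC1CCNCC1)[C@H]1CCCc3cccnc31)C2` differs from compound 1 by piperidin-4-yl in place of piperidin-3-yl on a saturated chain carbon, two bonds along the chain from an amine nitrogen. Going by the values given here, no measured step touches this position; compounds 2 and 3 differ from compound 1 in more than one place, so their higher numbers cannot be assigned to the piperidine alone. The expected step in this assay is therefore a number 3 percentage points higher from compound 1 to compound 4 (within the scatter), within the scatter. Compound 4 is estimated at 58%, with a range from 40% to 76%.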

Compound 4, percent of the compound remaining: 17%
Estimate against measurement, compound 4: 41 percentage points above; the whole stated range lies above it.
By their numbers in this assay, from the lowest: compound 4; then compound 1; then compounds 3 and 2 (each within the scatter of the next).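

Working notes: the attachment point on the piperidine matters at this position in this assay. For the compounds shown here, with the same atoms joined differently, piperidin-4-yl in place of piperidin-3-yl gives a number 38 percentage points lower from compound 1 to compound 4 (beyond the scatter), so this saturated chain carbon, two bonds along the chain from an amine nitrogen, tolerates no free swap between these two groups, which the earlier compounds could not show. No supporting data bear on what lies behind this step.

Open, as far as these compounds go, is how piperidin-2-yl or pyrrolidin-3-yl would read at this position. Also open, from the compounds shown here alone, is what the opposite configuration at the defined stereocentre of piperidin-3-yl would give.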